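This account rests on a few compounds, and the source may have more. Where it says the series, first, only, none or still open, it means among the compounds named here.

Compound 3 `COc1cccc(C(=O)NNC(=O)c2ccc3[nH]c(-c4ccc([N+](=O)[O-])o4)nc3c2)c1` gives the lowest of the three numbers in a functional assay on M14 cells (Homo sapiens) for inhibition, read by sulforhodamine B assay, with a stated time of 48 h (on this read-out lower numbers stand for stronger inhibition of growth and higher numbers for weaker inhibition of growth), at 7.81 ug/mL. Compound 1 `COc1cccc(C(=O)NNC(=O)c2ccc3[nH]c(-c4ccc([N+](=O)[O-])s4)nc3c2)c1` gives 15.6 ug/mL and compound 2 `COc1cc(C(=O)NNC(=O)c2ccc3[nH]c(-c4ccc([N+](=O)[O-])o4)nc3c2)cc(OC)c1OC` gives 15.6 ug/mL; both gaps to compound 3 are within the scatter, so no ordering among the three can be claimed. Among the measured compounds shown here, the single measured step, a 2.0-fold lower number from compound 1 to compound 3 (0.30 log units; within the scatter), changes the nitro-bearing five-membered ring and lies within the scatter.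

Compound 4 `O=C(NNC(=O)c1ccc2[nH]c(-c3ccc([N+](=O)[O-])o3)nc2c1)c1ccccc1` differs from compound 3 by hydrogen in place of methoxy on an aromatic carbon. For the measured compounds named here, no measured step touches the methoxyphenyl part directly. Compound 1 with one methoxy group and compound 2 with three methoxy groups give the same number, but they also differ in the nitro-bearing ring, so this pair shows only that two different methoxy patterns gave equal values. On this thin basis, the removal of a methoxy group is expected to give no step beyond the scatter, a 1.3-fold higher number from compound 3 to compound 4 (0.11 log units; within the scatter). Compound 4 is therefore estimated at 10 ug/mL, within a range from 4 ug/mL to 25 ug/mL.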

Compound 4, concentration for 50% growth inhibition: 15.6 ug/mL
For compound 4 the middle estimate is 1.6-fold (0.19 log units) below the measured one; the measured number falls inside the stated range.
By their numbers in this assay, from the lowest: compounds 3, 1, 2 and 4 (each within the scatter of the next).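

Among the compounds shown here, for the first time, a change on the 3-methoxyphenyl part is read directly: in this assay, going from 3-methoxyphenyl to phenyl gives a 2.0-fold higher number from compound 3 to compound 4 (0.30 log units; within the scatter). With the rest of the molecule held constant, the methoxy group at this place is therefore not needed for a value within the scatter of the methoxy compound. Nothing available bears on the cause of this result.

The compounds shown leave open whether a different group at this place, such as an amine, a carboxylic acid or a chlorine atom, would move the number beyond the scatter. As far as these compounds go, it also remains open whether the same exchange of methoxy for hydrogen would read the same way on the compound carrying the 5-nitrothiophen-2-yl group.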